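Replacing amino with nitro in compound 2

A few compounds are considered here, and "the series" means these few. Any claim that something is new, unique, unknown or untested is made for them only; others in the source may bear on it.

Measured in a functional assay on B16-F0 cells (Mus musculus) for inhibition, read by CCK-8 assay, with a stated time of 48 h; on this read-out higher numbers stand for weaker inhibition and lower numbers for stronger inhibition:
- compound 1 `COc1ccc(-c2cc3nccc(-c4cc(OC)c(OC)c(OC)c4)n3n2)cc1`: 1410 nM
- compound 2 `COc1ccc(-c2cc3nccc(-c4cc(OC)c(OC)c(OC)c4)n3n2)cc1N`: 88 nM

In this assay, compound 2 has the lower of the two numbers, at 88 nM, and so shows the stronger inhibition. The next compound, compound 3 `COc1ccc(-c2cc3nccc(-c4cc(OC)c(OC)c(OC)c4)n3n2)cc1[N+](=O)[O-]`, carries nitro in place of amino on an aromatic carbon.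

Among the measured compounds shown here, only one measured step bears on this change, and it is large: a 16-fold lower number from compound 1 to compound 2 (1.20 log units; beyond the scatter), with amino in place of hydrogen on an aromatic carbon. For the measured compounds named here, no nitro compound has been measured, so this step offers only an indirect guide. Since compound 3 lacks the amino group, much of that gain is expected to be lost, giving a higher number beyond the scatter. The expected change is an 8.0-fold higher number from compound 2 to compound 3 (0.90 log units; beyond the scatter). For compound 3 the estimated value is 700 nM, with an expected range of 200 nM to 2500 nM.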

Compound 3, half-maximal inhibitory concentration: > 10000 nM
Compound 3 ended at the assay's limit (the forecaster's own chance of this, stated with the estimate: 5%); at least 14-fold (1.15 log units) between middle value and limit.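

Compound 3 stands at a limit of the assay and not at a number: the limit of > 10000 nM in this assay, at which 1 of the 3 values shown sits. Read as a lower bound, the swap of amino for nitro gives an at least 110-fold higher number from compound 2 to compound 3 (2.05 log units; beyond the scatter), and set against hydrogen on the same aromatic carbon, nitro gives an at least 7.0-fold higher number from compound 1 to compound 3 (0.85 log units; beyond the scatter). Among the compounds shown here, the earlier step showed only that amino lowers the number, whereas this carbon, ortho to a methoxy group, now moves the read-out in both directions, so what matters is which group sits there and not merely that hydrogen is replaced.

The compounds shown leave open how a hydroxyl, a methylamino or an acetamido group would read at this carbon. They also leave open how far beyond the limit compound 3 really lies.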